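Acetyl in place of nitro: a step from a limit

The source may report more compounds than this note shows. Statements on the series, on what has been measured and on what is new or still open speak of the compounds shown alone.

Measured compounds:
compound 1, `COc1ccccc1N/N=C1\CCC(C)n2c1ncc(C(=O)O)c2=O`, in a functional assay on the whole organism for inhibition, with Rattus norvegicus as the target (a higher number here means that more compound is needed for the effect, a lower number that less compound is needed), gives > 1000 umol/kg
compound 2, `CC1CC/C(=N\Nc2ccccc2[N+](=O)[O-])c2ncc(C(=O)O)c(=O)n21`, in this assay gives > 1000 umol/kg

Both readings shown are limits of the assay and not numbers. For compound 1 the reading is a limit. For compound 2 the reading is likewise a limit, so compound 2 stands at the upper edge of what this assay reports, as summarised in the limit of > 1000 umol/kg in this assay, at which 2 of the 2 values shown sit. Within the data shown here, the one measured step, a step that the two limits leave unreadable from compound 1 to compound 2, has both ends at that limit, and its size cannot be read.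

Compound 3 is `CC(=O)c1ccccc1N/N=C1\CCC(C)n2c1ncc(C(=O)O)c2=O`. Relative to compound 2 the change is acetyl in place of nitro on an aromatic carbon.

Among the measured compounds shown here, no measured step bears readably on this change, and there is no numerical foothold for compound 2. The expectation for compound 3 in this assay therefore rests on compound 2 alone, whose reading > 1000 umol/kg is a limit, and compound 3 is most likely expected to return a limit as well. The step that the limit leaves unreadable from compound 2 to compound 3 is expected to be none beyond the scatter. The estimate for compound 3 is 1500 umol/kg, with a range from 400 umol/kg to 6000 umol/kg.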

Compound 3, dose for 50% inhibition: > 1000 umol/kg
Compound 3: only a limit was reported (the forecaster's own chance of this, stated with the estimate: 80%); the middle value lies beyond the limit too.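

No step can be read among compound 1, compound 2 and compound 3 in this assay, since each of the three readings is a limit and not a number: the limit of > 1000 umol/kg in this assay, at which 3 of the 3 values shown sit. The compounds shown leave open how far beyond the limit each one lies, and whether methoxy, nitro and acetyl on the aromatic carbon differ at all.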